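This account rests on a few compounds, and the source may have more. Where it says the series, first, only, none or still open, it means among the compounds named here.

Compound 1 `COc1cccc(/C=C/C(=O)c2sc(Nc3ccc(Cl)cc3)nc2C)c1`: in a functional assay on BGC-823 cells (Homo sapiens) for cytotoxicity, read by MTT assay (a higher number here means a weaker inhibitor, a lower number a stronger inhibitor), compound 1 gives > 25000 nM, a limit of the assay.
Compound 2 `Cc1ccccc1Nc1nc(C)c(C(=O)/C=C/c2ccc(Cl)cc2)s1`: in this assay compound 2 gives > 25000 nM, a limit of the assay.
Compound 3 `Cc1ccc(Nc2nc(C)c(C(=O)/C=C/c3ccc(Cl)cc3)s2)cc1`: in this assay compound 3 gives > 25000 nM, a limit of the assay.

Compound 3 stands, like the other two, at the limit of > 25000 nM in this assay, at which 3 of the 3 values shown sit; no number separates them. For the measured compounds named here, the one step between measured compounds, a step that the two limits leave unreadable from compound 2 to compound 3, cannot be read in size. Compound 4 `Cc1nc(Nc2ccc(Cl)cc2)sc1C(=O)/C=C/c1ccc(Cl)cc1` differs from compound 3 by chloro in place of methyl on an aromatic carbon. Going by the values given here, no measured step bears on this change, and the only step measured is unreadable, so no direction beyond the scatter can be foreseen. Compound 4 is therefore expected to give 30000 nM in this assay, within 12000 nM to 100000 nM. The step that the limit leaves unreadable from compound 3 to compound 4 that this estimate means is expected to be none beyond the scatter.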

Compound 4, half-maximal inhibitory concentration: > 25000 nM
Compound 4: no number, only a limit; the forecaster's own chance of this, stated with the estimate: 80%; the middle value lies beyond the limit too.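

For the compounds shown here, no step from compound 1, compound 2 or compound 3 to compound 4 can be read: all four compounds give only a limit of the assay, not a number. The compounds shown leave open how strongly each acts in this assay and whether any change on the shared core moves that value.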